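Urea series on the shared core: chloro for trifluoromethyl

The source may hold more compounds than are shown below. What is called first, only, known or untested is meant among the compounds shown, and "the series" means these compounds.

Three compounds on the shared core have numbers in a functional assay on A549 cells (Homo sapiens) for inhibition, read by sulforhodamine B assay, with a stated time of 48 h, tested at 10 uM; on this read-out higher numbers stand for a weaker effect at the one concentration tested and lower numbers for a stronger effect. Compound 1 `COc1cc(Cl)cc(-c2nn(-c3cccc(NC(=O)c4ccc(Cl)c(Cl)c4)c3)cc2-c2ccncc2)c1` carries the amide and gives 59.7%. Compound 2 `O=C(Nc1cccc(-n2cc(-c3ccncc3)c(-c3cc(O)cc(Cl)c3)n2)c1)Nc1ccc(Cl)c(Cl)c1` gives 3.96%. Compound 3 `COc1cc(Cl)cc(-c2nn(-c3cccc(NC(=O)Nc4ccc(Cl)c(C(F)(F)F)c4)c3)cc2-c2ccncc2)c1` gives 5.2%, which is the second highest of the three; its nearest neighbour is compound 2, a difference within the scatter, and its furthest is compound 1, beyond the scatter. Going by the values given here, the one step that can be read, a number 54.5 percentage points lower from compound 1 to compound 3 (beyond the scatter), concerns the amide-to-urea exchange and not the substituent on the outer ring.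

Compound 4 `COc1cc(Cl)cc(-c2nn(-c3cccc(NC(=O)Nc4ccc(Cl)c(Cl)c4)c3)cc2-c2ccncc2)c1` differs from compound 3 only by chloro in place of trifluoromethyl on an aromatic carbon. Among the compounds with values here, no measured step bears directly on this change. Compound 2, which already carries the 3,4-dichlorophenyl urea, sits within the scatter of compound 3, so no step beyond the scatter is expected in this assay for compound 4, and a number 0.2 percentage points lower from compound 3 to compound 4 (within the scatter) is the estimated step. Compound 4 is therefore expected to give about 5%, within 1% to 15%.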

Compound 4, a percentage reported as activity, at one concentration (the size of the read-out at that concentration, not a potency): 11.4%
Estimate against measurement, compound 4: 6.4 percentage points below; low and high end bracket the measured number.
By their numbers in this assay, from the lowest: compounds 2, 3 and 4 (each within the scatter of the next); then compound 1.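

In this assay, chloro in place of trifluoromethyl on an aromatic carbon ortho to a chloro group gives a number 6.2 percentage points higher from compound 3 to compound 4 (within the scatter) on the urea, and methyl in place of hydrogen on the oxygen of the aromatic ring gives a number 7.4 percentage points higher from compound 2 to compound 4 (within the scatter), so neither change moves the number beyond the scatter. With the 3,4-dichlorophenyl group held constant, the exchange of amide for urea gives a number 48.3 percentage points lower from compound 1 to compound 4 (beyond the scatter), which shows that the large step also appears without trifluoromethyl on the outer ring. No measurement on hand accounts for these steps.

On these data alone, what a nitrile or a methoxy group would do on this aromatic carbon remains open. So does the effect of an amine or a longer chain on the oxygen of the aromatic ring, and at the one concentration tested none of compounds 2, 3 and 4 can be told to have a stronger or weaker effect than the others.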